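Swapping a difluorophenyl for a pyrazole on a thiophene core

This account rests on a few compounds, and the source may have more. Where it says the series, first, only, none or still open, it means among the compounds named here.

Of the compounds shown here, three built on the same aminothiophene core have been tested in an assay on CHO cells for displacement of a labelled ligand from adenosine receptor A3 (Homo sapiens), read by scintillation counting, tested at 10 uM; on this read-out lower numbers stand for less inhibition and higher numbers for more inhibition at the one concentration tested (going by the name of the read-out). Compound 1 `CC(C)(C)c1csc(N)c1C(=O)c1ccc(Cl)cc1` gives 1%. Compound 2 `CC(C)(C)Cc1c(-c2cc(F)ccc2F)sc(N)c1C(=O)c1ccc(Cl)cc1` gives 1%, and compound 3 `CC(C)(C)Cc1c(-c2ccccc2)sc(N)c1C(=O)c1ccccc1Cl` gives 1%. At the digits shown compound 2 stands level with both compound 1 and compound 3, and all three are within the usual scatter of one another, so none can be called stronger or weaker.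

The next compound, compound 4 `CC(C)(C)Cc1c(-c2cn[nH]c2)sc(N)c1C(=O)c1ccc(Cl)cc1`, differs from compound 2 in a single place: 1H-pyrazol-4-yl in place of 2,5-difluorophenyl on an aromatic carbon. For the measured compounds named here, since every compound measured so far sits at the same low reading, there is no step between measured compounds to lean on, and the expected step in this assay from compound 2 to compound 4 is estimated as a number 2 percentage points higher from compound 2 to compound 4 (within the scatter), that is, none beyond the scatter in either direction. On that basis compound 4 is expected to give about 3%, with a likely range from 0% to 15%.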

Compound 4, a percentage reported as inhibition, at one concentration (the size of the read-out at that concentration, not a potency): 1%
The estimate for compound 4 lay 2 percentage points above the measured number, within the range that was stated.
By their numbers in this assay, from the lowest: compounds 1, 2, 3 and 4 (each within the scatter of the next).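

For the compounds shown here, this is the first matched pair, and in this assay the step is no change at the digits printed from compound 2 to compound 4 (within the scatter). On the aromatic carbon next to the ring sulfur, 1H-pyrazol-4-yl brings a smaller ring with a hydrogen-bond donor and a hydrogen-bond acceptor in place of 2,5-difluorophenyl, which has neither, yet the single-concentration reading stays low. No measurement here accounts for that result.

As far as these compounds go, whether an amine or a carboxylic acid on this carbon, or a longer chain in place of the neopentyl group, would lift the reading beyond the scatter remains open. With both members of the pair this low, it is also unclear whether this position can influence the reading at all.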